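A few compounds are considered here, and "the series" means these few. Any claim that something is new, unique, unknown or untested is made for them only; others in the source may bear on it.

The measured compounds:
Compound 1, `CN(c1cccc2c1CN(c1nc(Nc3ccc(C(F)(F)F)cc3)ncc1C(F)(F)F)C2)S(C)(=O)=O`, in a functional assay on HeLa cells (Homo sapiens) for antiproliferative activity, read by spectrophotometry, with a stated time of 2 days (a higher number here means a weaker inhibitor of growth, a lower number a stronger inhibitor of growth), gives > 30000 nM, which is a limit of the assay and not a number.
Compound 2, `CN(c1cccc2c1CN(c1nc(Nc3cc(Cl)cc(C(F)(F)F)c3)ncc1C(F)(F)F)C2)S(C)(=O)=O`, gives 4300 nM in this assay.
Compound 3, `Cc1ccc(Nc2ncc(C(F)(F)F)c(N3Cc4cccc(N(C)S(C)(=O)=O)c4C3)n2)cc1C`, gives > 30000 nM in this assay, again a limit and not a number.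

Compound 1 stands at the limit of > 30000 nM in this assay, at which 2 of the 3 values shown sit, so only a limit is known for it. Compound 4, `CN(c1cccc2c1CN(c1nc(Nc3ccc(Nc4ccccc4)cc3)ncc1C(F)(F)F)C2)S(C)(=O)=O`, differs from compound 1 by anilino in place of trifluoromethyl on an aromatic carbon. The measured steps all alter the aryl group on the nitrogen, not the place changed here: an at least 6.9-fold lower number from compound 1 to compound 2 (0.84 log units; beyond the scatter), an at least 6.9-fold higher number from compound 2 to compound 3 (0.84 log units; beyond the scatter), and a step that the two limits leave unreadable from compound 1 to compound 3. None of them bears on the change from compound 1 to compound 4, so no direction can be read from them. Compound 4 is therefore expected to remain a weak inhibitor, the expected step being an at least 1.5-fold lower number from compound 1 to compound 4 (0.17 log units; that floor lies within the scatter). The estimate for compound 4 is 20000 nM, with a range from 3000 nM to 30000 nM.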

Compound 4, concentration for 50% growth inhibition: 7300 nM
Beside the measured number, compound 4's estimate is 2.7-fold (0.44 log units) above it, within the range that was stated.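

Anilino in place of trifluoromethyl, on an aromatic carbon para to a large group, gives in this assay an at least 4.1-fold lower number from compound 1 to compound 4 (0.61 log units; beyond the scatter). The earlier steps shown here exchanged the whole aryl group on the nitrogen, whereas this one shows that a single change at this place, bringing in a further aromatic ring of carbon only, is enough to give a measurable value. Its size is only a floor, since compound 1 has a limit and not a number: the limit of > 30000 nM in this assay, at which 2 of the 4 values shown sit.

The compounds shown leave open whether the step belongs to the added ring or to its linking nitrogen. A phenoxy group or a simple amine at this place would separate the two.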